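Compound 3 and the change from compound 1

The source may hold more compounds than are shown below. What is called first, only, known or untested is meant among the compounds shown, and "the series" means these compounds.

In an ADME assay on the whole organism (strain Sprague-Dawley) for metabolic stability, with Rattus norvegicus as the target, read by LC-MS (on this read-out higher numbers stand for a longer-lived compound and lower numbers for a shorter-lived compound), compound 1 (`O=c1[nH]ccn1CCOc1nn(-c2ccccc2F)c2ccc(F)cc12`) gives 0.4 h and compound 2 (`O=C1NCCN1CCOc1nn(-c2ccc(F)cc2)c2ccc(F)cc12`) gives 0.7 h as a half-life, so these two stand within the scatter of each other. Compound 3 (`O=C(COc1nn(-c2ccccc2F)c2ccc(F)cc12)N1CCOCC1`) is still unmeasured. It differs from compound 1 in one place (a group of 8 heavy atoms (5 carbon, 1 nitrogen, 2 oxygen; one six-membered non-aromatic ring with 2 hetero atoms) in place of a group of 7 heavy atoms (4 carbon, 2 nitrogen, 1 oxygen; one five-membered aromatic ring with 2 hetero atoms), on a saturated chain carbon bound to an oxygen on an aromatic ring), on a saturated chain carbon bound to an oxygen on an aromatic ring. Among the compounds with values here, no measured step covers this change. The expected step in this assay (a 1.5-fold higher number from compound 1 to compound 3 (0.18 log units; within the scatter)) is small and upward, not beyond the scatter. For compound 3 the estimated half-life is 0.6 h (expected range 0.25 h to 1.4 h).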

Compound 3, half-life: 1.6 h
Compound 3: the middle estimate sits 2.7-fold (0.43 log units) below what was measured, outside the stated range (above it).
By their numbers in this assay, from the lowest: compounds 1 and 2 (each within the scatter of the next); then compound 3.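

Within the data shown here, at the saturated chain carbon bound to an oxygen on an aromatic ring, (morpholin-4-yl)carbonyl in place of the five-membered aromatic ring group gives, in this assay, a 4.0-fold higher number from compound 1 to compound 3 (0.60 log units; beyond the scatter), the only step at this place and one beyond the scatter. The change also removes the hydrogen-bond donor, and this single step cannot separate that loss from the change of ring. Nothing at hand accounts for the size of the step.

Going by these compounds, whether the higher number follows the ring oxygen of (morpholin-4-yl)carbonyl or the loss of the donor stays open. A piperidine amide or a dimethylamine amide at the same place would bear on this.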